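Extending the Urea Tail of Compound 3

This account rests on a few compounds, and the source may have more. Where it says the series, first, only, none or still open, it means among the compounds named here.

Compound 1 `CCN(CC)CCNC(=O)Nc1nc2ccc(-c3cnc(OC)c(NS(=O)(=O)c4ccc(C)cc4)c3)cn2n1` gives 410 nM in a functional assay on MCF7 cells (Homo sapiens) for cytotoxicity, read by MTT assay, with a stated time of 72 h; a lower number here means a stronger inhibitor, a higher number a weaker inhibitor. Compound 2 `CCN(CC)CCNC(=O)Nc1nc2ccc(-c3cnc(OC)c(NS(=O)(=O)c4ccc(F)cc4F)c3)cn2n1` gives 740 nM. Compound 3 `CNC(=O)Nc1nc2ccc(-c3cnc(OC)c(NS(=O)(=O)c4ccc(F)cc4)c3)cn2n1` gives 250 nM.

Compound 3 stands at the lowest of the three numbers, though its gap to compound 1 lies within the usual scatter and only its gap to compound 2 lies beyond it. Compound 4 `COc1ncc(-c2ccc3nc(NC(=O)NCC(=O)N4CCCCC4)nn3c2)cc1NS(=O)(=O)c1ccc(F)cc1` differs from compound 3 by (piperidin-1-yl)carbonyl in place of hydrogen on a saturated chain carbon bound to an amide-type nitrogen. Among the measured compounds shown here, the one measured single-point step, a 1.8-fold higher number from compound 1 to compound 2 (0.26 log units; within the scatter), concerns the sulfonyl aryl group, not this position, so no measured step bears directly on the change. Compounds 1 and 3, which differ at the urea tail and elsewhere, show values within the scatter of each other. The number for compound 4 is therefore expected to be about 350 nM, ranging from 120 nM to 1000 nM. This estimate means an expected step of a 1.4-fold higher number from compound 3 to compound 4 (0.15 log units; within the scatter).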

Compound 4, half-maximal inhibitory concentration: 570 nM
Beside the measured number, compound 4's estimate is 1.6-fold (0.21 log units) below it; measured number inside the range.
By their numbers in this assay, from the lowest: compounds 3, 1, 4 and 2 (each within the scatter of the next, the first and the last beyond it).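

Replacing methyl with ((piperidin-1-yl)carbonyl)methyl on the urea tail gives a 2.3-fold higher number from compound 3 to compound 4 (0.36 log units; beyond the scatter) in this assay. This is the first step shown at this position, and it shows that a much larger tail, with a six-membered ring and a carbonyl, raises the number only modestly. Nothing shown explains why the number rises.

As far as these compounds go, it remains open whether the ring or the carbonyl accounts for the step. A plain propyl chain or a morpholin-4-yl amide at the same place would help separate the two.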